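Varying the Group on the Carbonyl-Bound Oxygen

A few compounds are considered here, and "the series" means these few. Any claim that something is new, unique, unknown or untested is made for them only; others in the source may bear on it.

Of the compounds shown here, three built on a shared core have been measured in an assay on isolated protein for inhibition of Rho-associated protein kinase 2 (Homo sapiens), read by radiometric assay; on this read-out lower numbers stand for stronger inhibition and higher numbers for weaker inhibition. Compound 1 `NCc1ccc(C(=O)Nc2ccncc2F)cc1-c1cccc(C(=O)Oc2ccccc2)c1` gives 6.2 nM. Compound 2 `CC(C)OCCOC(=O)c1cccc(-c2cc(C(=O)Nc3ccncc3F)ccc2CN)c1` gives 37 nM in this assay, and compound 3 `COC(=O)c1cccc(-c2cc(C(=O)Nc3ccncc3F)ccc2CN)c1` gives 7.8 nM. Compound 3 thus stands second highest of the three numbers, nearest to compound 1 and furthest from compound 2. Every step among them changes the group on an oxygen next to a carbonyl group: a 1.3-fold higher number from compound 1 to compound 3 (0.10 log units; within the scatter), a 6.0-fold higher number from compound 1 to compound 2 (0.78 log units; beyond the scatter) and a 4.7-fold lower number from compound 2 to compound 3 (0.68 log units; beyond the scatter). Compound 4 `NCc1ccc(C(=O)Nc2ccncc2F)cc1-c1cccc(C(=O)OC2CCCOC2)c1` has not yet been measured; relative to compound 3 its change is oxan-3-yl in place of methyl on an oxygen next to a carbonyl group. The steps from compound 1 to compound 3 and from compound 2 to compound 3 bear on this: a larger group without an oxygen stayed within the scatter, whereas the chain carrying an oxygen gave a modest rise. Oxan-3-yl brings one six-membered non-aromatic ring with 1 hetero atom, so a small rise is expected, a 1.9-fold higher number from compound 3 to compound 4 (0.28 log units; within the scatter). Compound 4 is therefore estimated at 15 nM, with an expected range from 6 nM to 45 nM.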

Compound 4, half-maximal inhibitory concentration: 8.7 nM
The estimate for compound 4 lay 1.7-fold (0.24 log units) above the measured number, within the range that was stated.
By their numbers in this assay, from the lowest: compounds 1, 3 and 4 (each within the scatter of the next); then compound 2.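

Oxan-3-yl brings a ring oxygen to the oxygen next to a carbonyl group, yet the change gives a 1.1-fold higher number from compound 3 to compound 4 (0.05 log units; within the scatter) and stays within the scatter, as does the comparison with the phenyl group, which gives a 1.4-fold higher number from compound 1 to compound 4 (0.15 log units; within the scatter) and leaves methyl, phenyl and oxan-3-yl indistinguishable here. For the compounds shown here, an oxygen within the group therefore does not by itself go with a weaker number, since 2-isopropoxyethyl remains the one group set apart, with a 4.3-fold lower number from compound 2 to compound 4 (0.63 log units; beyond the scatter) in this comparison. The compounds offer no evidence on why the open chain and the ring differ.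

On these data alone, it remains open how a carboxylic acid or an amide would read in place of the ester. Also open, as far as these compounds go, is whether a shorter chain such as 2-methoxyethyl would fall with compound 2 or with the other three.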